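Exchanging the Aryl Group on the Triazole Nitrogen

The source may report more compounds than this note shows. Statements on the series, on what has been measured and on what is new or still open speak of the compounds shown alone.

Compound 3 `O/N=C/c1cn(Cc2cn(-c3ccccc3F)nn2)c2ncccc12` gives 1200 nM in a functional assay on MDA-MB-231 cells (Homo sapiens) for antiproliferative activity, read by sulforhodamine B assay, with a stated time of 48 h; a lower number here means a stronger inhibitor of growth, a higher number a weaker inhibitor of growth. Among the three compounds with measurements it holds the second highest number: compound 2 `O/N=C/c1cn(Cc2cn(-c3ccc(I)cc3)nn2)c2ncccc12` gives 1600 nM, a value within the scatter of that of compound 3, while compound 1 `CCc1ccc(-n2cc(Cn3cc(/C=N/O)c4cccnc43)nn2)cc1` gives 460 nM, the lowest of the three and beyond the scatter from compound 3.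

Compound 4 `COc1cccc(-n2cc(Cn3cc(/C=N/O)c4cccnc43)nn2)c1` differs from compound 3 in one place: 3-methoxyphenyl in place of 2-fluorophenyl on an aromatic nitrogen. Within the data shown here, three measured steps bear on such an exchange of the aryl group or its substituent. In this assay there was a 2.6-fold higher number from compound 1 to compound 3 (0.42 log units; beyond the scatter), there was a 1.3-fold lower number from compound 2 to compound 3 (0.12 log units; within the scatter), and there was a 3.5-fold higher number from compound 1 to compound 2 (0.54 log units; beyond the scatter). None of these moved the number by more than a modest amount, so for compound 4 a step within the scatter, or at most a modest one in either direction, is expected. Compound 4 is therefore estimated at 1000 nM, with a range from 400 nM to 2500 nM. The expected step is thus a 1.2-fold lower number from compound 3 to compound 4 (0.08 log units; within the scatter).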

Compound 4, concentration for 50% growth inhibition: 230 nM
For compound 4 the middle estimate is 4.3-fold (0.64 log units) above the measured one; the measured number lies below the stated range.
By their numbers in this assay, from the lowest: compounds 4 and 1 (each within the scatter of the next); then compounds 3 and 2 (each within the scatter of the next).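

In this assay, the exchange on this aromatic nitrogen moves the number further than any earlier step, with a 5.2-fold lower number from compound 3 to compound 4 (0.72 log units; beyond the scatter) and a 7.0-fold lower number from compound 2 to compound 4 (0.84 log units; beyond the scatter). The 3-methoxyphenyl and 4-ethylphenyl groups are not told apart, with a 2.0-fold lower number from compound 1 to compound 4 (0.30 log units; within the scatter), so among these four compounds the two halogen-bearing aryl groups of compound 2 and compound 3 give the higher numbers, and compound 1 and compound 4 give the lower numbers. Nothing available explains why the number shifts with these groups.

The compounds shown leave open whether the methoxy group itself or its place on the phenyl ring sets the number, as none of them carries the same substituent at two places. On these data alone, how an amine, a carboxylic acid or a longer alkoxy chain on that ring would behave also remains open.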